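Working notes: from compound 2 to compound 4

A few compounds are considered here, and "the series" means these few. Any claim that something is new, unique, unknown or untested is made for them only; others in the source may bear on it.

Measured in a functional assay on HeLa cells (Homo sapiens) for inhibition, with a stated time of 72 h; a higher number here means that more compound is needed for the effect, a lower number that less compound is needed:
- compound 1 `COc1cc(OCc2cnc(Cl)c(Cl)c2)ccc1CNCc1ccncc1` gives 400 nM
- compound 2 `COc1cc(CNCc2ccncc2)ccc1OCc1ccc(F)cc1` gives 6400 nM
- compound 3 `COc1cc(OCc2ccc(Cl)cc2)ccc1CNCc1ccncc1` gives 440 nM

Compound 2 has the highest of the three numbers and lies beyond the scatter from both compound 1 and compound 3. The next compound is compound 4 `COc1cc(CNCc2ccncc2)ccc1OCc1ccc(Cl)nc1` with the change 6-chloropyridin-3-yl in place of 4-fluorophenyl on a saturated chain carbon bound to an oxygen on an aromatic ring on a saturated chain carbon bound to an oxygen on an aromatic ring. Among the compounds with values here, the one measured step that bears on this is a 1.1-fold higher number from compound 1 to compound 3 (0.04 log units; within the scatter) for 4-chlorophenyl in place of 5,6-dichloropyridin-3-yl. It suggests that a pyridine ring and a benzene ring can give matching numbers, though on the core of compound 1, which differs from that of compound 2. Within the data shown here, compound 3 at 440 nM carries a chlorine, as compound 4 does, but no measured pair separates the halogen from the core. A partial move is therefore expected, and a 2.6-fold lower number from compound 2 to compound 4 (0.41 log units; beyond the scatter) is the estimated step in this assay with wide uncertainty. Compound 4 is estimated at 2500 nM with an expected range from 800 nM to 7000 nM for now.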

Compound 4, half-maximal effective concentration: 400 nM
Compound 4: the middle estimate sits 6.3-fold (0.80 log units) above what was measured; measured number below the stated range.
By their numbers in this assay, from the lowest: compounds 1, 4 and 3 (each within the scatter of the next); then compound 2.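

In this assay the change to 6-chloropyridin-3-yl in place of 4-fluorophenyl on a saturated chain carbon bound to an oxygen on an aromatic ring gives a 16-fold lower number from compound 2 to compound 4 (1.20 log units; beyond the scatter) and shows that the number is sensitive to the group at this place on the shared core of these two compounds. The earlier ring change at this place, a 1.1-fold higher number from compound 1 to compound 3 (0.04 log units; within the scatter) on the core of compound 1, stayed within the scatter, so a swap here does not always leave the number unmoved. Nothing in the data at hand accounts for the size of the new step.

Within the data shown here, open is whether the step belongs to the ring nitrogen or to the chlorine: the change brings in both at once, and no pair on this core moves one alone. Also open, going by these compounds, is how this place responds to a carboxylic acid on the ring or to a longer chain in place of the single saturated carbon.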